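A few compounds are considered here, and "the series" means these few. Any claim that something is new, unique, unknown or untested is made for them only; others in the source may bear on it.

Working notes on the series. In a functional assay on A549 cells (Homo sapiens) for cytotoxicity, read by MTT assay, with a stated time of 48 h (a lower number here means a stronger inhibitor, a higher number a weaker inhibitor), compound 3 (`C=C(c1ccc(OC)cc1)c1cc(OC)c(OC)c(OC)c1-c1ccc(F)c(F)c1`) gives (6500 nM) and shares the low end of the three numbers with compound 1 (`COc1ccc(/C=C/c2cc(OC)c(OC)c(OC)c2-c2ccc(F)c(F)c2)cc1`), which gives (7500 nM), the two lying within the scatter of each other. Compound 2 (`C=C(c1ccc(OC)cc1)c1cc(OC)c(OC)c(OC)c1-c1ccc(OC)cc1`) gives (14000 nM), a higher number than either.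

The next compound is compound 4 (`C=C(c1ccc(OC)cc1)c1cc(OC)c(OC)c(OC)c1-c1ccccc1`), with phenyl in place of 3,4-difluorophenyl on an aromatic carbon, ortho to a 1-(4-methoxyphenyl)ethenyl group (phenyl in place of 3,4-difluorophenyl on an aromatic carbon).

The measured step closest to this change is at the same place: 3,4-difluorophenyl in place of 4-methoxyphenyl (a 2.2-fold lower number from compound 2 to compound 3 (0.33 log units; beyond the scatter)), modest and only just beyond the scatter. The exchange of 2-(4-methoxyphenyl)ethenyl for 1-(4-methoxyphenyl)ethenyl (a 1.2-fold lower number from compound 1 to compound 3 (0.06 log units; within the scatter)) lies within the scatter and concerns another place, so it offers little guidance. Within the data shown here, no measured compound carries phenyl at this place, so the expectation rests on a single pair.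

A small rise in this assay is expected, placing compound 4 between the numbers of compound 3 and compound 2. The estimated change is a 1.5-fold higher number from compound 3 to compound 4 (0.19 log units; within the scatter) and would probably stay within the scatter. For compound 4 the estimated value is 10000 nM with an expected range from 5000 nM to 20000 nM for repeated measurements.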

Compound 4, half-maximal inhibitory concentration: 22000 nM
Estimate against measurement, compound 4: 2.2-fold (0.34 log units) below; the measured number lies above the stated range.
By their numbers in this assay, from the lowest: compounds 3, 1, 2 and 4 (each within the scatter of the next, the first and the last beyond it).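

In this assay, the step from 3,4-difluorophenyl to phenyl at this position, a 3.4-fold higher number from compound 3 to compound 4 (0.53 log units; beyond the scatter), shows that the low number of compound 3 depends on the two fluorines and is not shared by the unsubstituted ring. The exchange of methoxy for hydrogen, a 1.6-fold higher number from compound 2 to compound 4 (0.20 log units; within the scatter), gives no readable difference, so compound 2 and compound 4 stand together and the earlier step to compound 3 cannot be read as a simple gain from losing the methoxy group. Among the three rings seen at this place on the 1-(4-methoxyphenyl)ethenyl scaffold, only 3,4-difluorophenyl stands apart, and no measurement shown here explains why.

The compounds shown leave open whether a single fluorine would keep the low number of compound 3, or whether chlorine, trifluoromethyl, a nitrile or an amine on the same ring would behave like the fluorines or like hydrogen. As far as these compounds go, it also remains open whether the same loss on going to phenyl would appear with the 2-(4-methoxyphenyl)ethenyl group of compound 1.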